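Chlorophenyl swap from compound 3 to compound 4

This account rests on a few compounds, and the source may have more. Where it says the series, first, only, none or still open, it means among the compounds named here.

In a functional assay on HCT-116 cells (Homo sapiens) for antiproliferative activity, read by MTT assay, with a stated time of 72 h (a lower number here means a stronger inhibitor, a higher number a weaker inhibitor), compound 1 `Nc1nc(N)c2cc(CSC(=S)N3CCN(c4ccccc4)CC3)ccc2n1` gives 4120 nM, compound 2 `Cc1ccc(N2CCN(C(=S)SCc3ccc4nc(N)nc(N)c4c3)CC2)c(C)c1` gives 4070 nM and compound 3 `Nc1nc(N)c2cc(CSC(=S)N3CCN(c4ccc(Cl)cc4)CC3)ccc2n1` gives 7380 nM. Compound 3 stands level with the other two. The steps to it are a 1.8-fold higher number from compound 1 to compound 3 (0.25 log units; within the scatter) and a 1.8-fold higher number from compound 2 to compound 3 (0.26 log units; within the scatter), and the remaining step is a 1.0-fold lower number from compound 1 to compound 2 (0.01 log units; within the scatter).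

Compound 4 `Nc1nc(N)c2cc(CSC(=S)N3CCN(c4ccccc4Cl)CC3)ccc2n1` has the same atoms as compound 3, joined differently: 2-chlorophenyl in place of 4-chlorophenyl on an amine nitrogen in a ring. Going by the values given here, no measured compound carries the 2-chlorophenyl group, so no measured step tests this change directly. The closest evidence is the three changes on the same ring nitrogen, and even the largest of them, a 1.8-fold higher number from compound 2 to compound 3 (0.26 log units; within the scatter), stays within the scatter. No step beyond the scatter is therefore expected in this assay. The expected step is a 1.3-fold lower number from compound 3 to compound 4 (0.13 log units; within the scatter). For compound 4 the estimated value is 5500 nM, with an expected range of 2600 nM to 11500 nM.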

Compound 4, half-maximal inhibitory concentration: 5490 nM
Compound 4: the middle estimate sits 1.0-fold (0.00 log units) above what was measured; the range from low to high includes it.
By their numbers in this assay, from the lowest: compounds 2, 1, 4 and 3 (each within the scatter of the next).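

In this assay, going by these compounds alone, the chloro group changes position on the aryl ring for the first time, and the swap from 4-chlorophenyl to 2-chlorophenyl stays within the scatter (a 1.3-fold lower number from compound 3 to compound 4 (0.13 log units; within the scatter)). The 2-chlorophenyl group also stands level with phenyl (a 1.3-fold higher number from compound 1 to compound 4 (0.12 log units; within the scatter)) and with 2,4-dimethylphenyl (a 1.3-fold higher number from compound 2 to compound 4 (0.13 log units; within the scatter)), so no aryl group on this amine nitrogen in a ring has yet produced a step beyond the scatter. No measured evidence accompanies these steps to explain them.

From the compounds shown here alone, it remains open whether a group other than a substituted phenyl on this nitrogen, such as a benzyl or an acetyl, would give such a step. A carboxylic acid or an amine on the phenyl ring is equally untested in the compounds shown here.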